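The source may hold more compounds than are shown below. What is called first, only, known or untested is meant among the compounds shown, and "the series" means these compounds.

Three compounds were measured in an assay for binding affinity to Alpha-1B adrenergic receptor (Homo sapiens); on this read-out higher numbers stand for weaker inhibition and lower numbers for stronger inhibition:

Compound 1, `O=c1c2ccccc2c(Cc2ccc(Cl)cc2)nn1CCNCCCCc1ccc(OCCCN2CCCCCC2)cc1` — 316 nM
Compound 2, `CN(C)CCn1nc(Cc2ccc(Cl)cc2)c2ccccc2c1=O` — 200 nM
Compound 3, `CN1CCC[C@@H]1Cn1nc(Cc2ccc(F)cc2)c2ccccc2c1=O` — 79.4 nM

Compound 3 stands lowest of the three numbers. Its nearest neighbour is compound 2, whose value in this assay is 200 nM, a gap beyond the scatter of repeated measurements, and the furthest is compound 1, whose value in this assay is 316 nM, also beyond the scatter.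

Compound 4, `COc1ccc(Cc2nn(C[C@H]3CCCN3C)c(=O)c3ccccc23)cc1`, has not yet been measured in this assay. It differs from compound 3 in one place: methoxy in place of fluoro on an aromatic carbon. Within the data shown here, no pair of measured compounds shows this particular change, so there is no step to lean on. The shared core of compound 3 and compound 4 is kept, and the change is confined to the substituent on the six-membered aromatic ring of carbon only.

With nothing measured on this change, the expectation is for a step of no size beyond the scatter, in either direction, a 1.0-fold higher number from compound 3 to compound 4 (0.00 log units; within the scatter). Compound 4 is therefore expected to give about 80 nM in this assay, with a range from 30 nM to 250 nM.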

Compound 4, inhibition constant: 158 nM
Compound 4: middle estimate off by 2.0-fold (0.30 log units), on the low side, within the range that was stated.
By their numbers in this assay, from the lowest: compounds 3, 4, 2 and 1 (each within the scatter of the next, the first and the last beyond it).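

In this assay, among these compounds, the change of methoxy in place of fluoro, on an aromatic carbon para to a large group, gives a 2.0-fold higher number from compound 3 to compound 4 (0.30 log units; within the scatter) with the rest of the molecule held fixed, a direct reading that no earlier pair of compounds offered. Across this single pair, the position accepts two heavy atoms, including a hydrogen-bond acceptor, in place of a single fluorine without a step beyond the scatter. No measured evidence bears on this result.

The compounds shown leave open whether a hydroxyl, a trifluoromethyl, an amine or a longer chain such as ethoxy at this position would also stay within the scatter of compound 3. They also leave open whether the same change would read alike with the side chain of compound 2 in place.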